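The source may report more compounds than this note shows. Statements on the series, on what has been measured and on what is new or still open speak of the compounds shown alone.

In a functional assay on HeLa cells (Homo sapiens) for antiproliferative activity, read by CCK-8 assay, with a stated time of 72 h (a lower number here means a stronger inhibitor of growth, a higher number a weaker inhibitor of growth), compound 1 `CC[C@@H]1C(=O)N(C)c2cnc(-n3ccc4cc(C(=O)NC)ccc43)nc2N1C1CCCC1` gives 768 nM and compound 2 `CCCNC(=O)c1ccc2c(ccn2-c2ncc3c(n2)N(c2ccn(C)n2)C(CC)C(=O)N3C)c1` gives 6160 nM as the higher of the two numbers. The gap lies beyond the scatter, which makes compound 2 the weaker growth inhibitor of this pair. Compound 3 `CCC1C(=O)N(C)c2cnc(-n3ccc4cc(C(N)=O)ccc43)nc2N1c1ccn(C)n1` is reached from compound 2 by one change. The change hydrogen in place of propyl on an amide-type nitrogen is hydrogen in place of propyl on an amide-type nitrogen. For the measured compounds named here, no measured pair shows this change alone, so the expectation is loose. It leans toward a lower number, and that lean rests only on compound 1 at 768 nM lying under compound 2 at 6160 nM on the same scale. The estimated move a 3.1-fold lower number from compound 2 to compound 3 (0.49 log units; beyond the scatter) is expected to be moderate in this assay and may prove no larger than the scatter. For compound 3 the expected value is 2000 nM with an estimated range from 600 nM to 7000 nM for the measurement.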

Compound 3, concentration for 50% growth inhibition: 27400 nM
Estimate against measurement, compound 3: 14-fold (1.14 log units) below, outside the stated range (above it).
By their numbers in this assay, from the lowest: compound 1; then compound 2; then compound 3.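

In this assay, for the compounds shown here, the single change from propylcarbamoyl to carbamoyl gives a 4.4-fold higher number from compound 2 to compound 3 (0.65 log units; beyond the scatter), the first step read with the rest of the structure held fixed. The substituent on this amide-type nitrogen therefore matters here, and in this pair the propyl goes with stronger growth inhibition than the amide hydrogen, although one pair sets no trend. No available evidence accounts for the direction or size of this step.

From the compounds shown here alone, whether a longer chain or a propyl chain ending in an amine or a carboxylic acid would lower the number further remains open. Also open, going by these compounds, is whether hydrogen in place of propyl has a similar effect when the other substituents of compound 1 are present.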